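One More Double Bond in a Long Chain

A few compounds are considered here, and "the series" means these few. Any claim that something is new, unique, unknown or untested is made for them only; others in the source may bear on it.

In a functional assay on MDA-MB-231 cells (Homo sapiens) for antiproliferative activity, read by MTT assay (on this read-out higher numbers stand for weaker inhibition and lower numbers for stronger inhibition), compound 3 `CCCCC/C=C\C/C=C\CCCCCCCc1cc(=O)c2c(O)cc(O)c(C)c2o1` gives 6790 nM. Compound 2 `CC/C=C\C/C=C\C/C=C\CCCCCCCc1cc(=O)c2c(O)cc(OCOC)cc2o1`, which has a different core, gives the same number, 6790 nM. Compound 1 `CCCC/C=C\CCCCCCCCCc1cc(=O)c2c(O)cc(OCOC)cc2o1` is reported as a limit of the assay, > 87000 nM, and not as an exact number.

Compound 4 `CC/C=C\C/C=C\C/C=C\CCCCCCCc1cc(=O)c2c(O)cc(O)c(C)c2o1` keeps the core of compound 3 and changes only the chain, with but-1-en-1-yl in place of butyl on a saturated chain carbon bound to a double-bonded chain carbon.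

Among the measured compounds shown here, only one measured step involves a chain change, and it is large: an at least 12-fold lower number from compound 1 to compound 2 (1.10 log units; beyond the scatter). That step is a weak guide here, since it starts from a limit and swaps a bigger piece of the chain than the change now in question. A closer clue comes from the chain itself. Compound 4 carries the chain of compound 2, and compound 2 sits at 6790 nM, level with compound 3 in this assay. No large shift is therefore expected, only a slight drift towards stronger inhibition at most. The estimated change is a 1.2-fold lower number from compound 3 to compound 4 (0.09 log units; within the scatter), which stays within the scatter. For compound 4 the expected value is 5500 nM, with an estimated range from 2400 nM to 12000 nM.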

Compound 4, half-maximal inhibitory concentration: 6790 nM
For compound 4 the middle estimate is 1.2-fold (0.09 log units) below the measured one; low and high end bracket the measured number.
By their numbers in this assay, from the lowest: compounds 2, 3 and 4 (each within the scatter of the next). At a limit, above all of these: compound 1.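

On the core shared by compound 3 and compound 4, putting but-1-en-1-yl in place of butyl on a saturated chain carbon bound to a double-bonded chain carbon leaves the result in this assay flat, with no change at the digits printed from compound 3 to compound 4 (within the scatter). This pair isolates the effect of one more double bond in the chain, which compound 2 and compound 3 could not do, as they differ in both core and chain; at this position, the change from butyl to but-1-en-1-yl leaves antiproliferative activity at the same level on this read-out. The data shown give no explanation for this flat result.

On these data alone, what the chain can tolerate beyond this single change remains open: a longer chain, a much shorter chain, or a chain ending in an amine or a carboxylic acid could show whether the number moves at all from this level on the same core. One flat pair also cannot say whether butyl and but-1-en-1-yl would behave alike on the core of compound 2.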